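The compounds below may be only part of what the source reports. "The series", "measured", "known", "first", "only" and "open" are said of these compounds alone.

Measured compounds in a physicochemical assay for permeability, using PAMPA, with a stated time of 4 h, at pH 7.4, tested at 50 uM; a higher number here means that the compound crosses the layer faster, a lower number that the compound crosses the layer more slowly:
compound 1 `Cc1c(CCCC(=O)O)c2cccc(/C=C/c3ccc(OCCCCc4c(F)cc(F)c(F)c4F)cc3)c2n1CC(=O)O` — 0.3 10^-6 cm/s
compound 2 `Cc1c(Cl)cccc1CCCCOc1ccc(C#Cc2cccc3c(CCCC(=O)O)c(C)n(CCCCC(=O)O)c23)cc1` — 5 10^-6 cm/s
compound 3 `Cc1c(Cl)cccc1CCCCOc1ccc(C#Cc2cccc3c(CC(=O)O)c(C)n(CCCCC(=O)O)c23)cc1` — 1 10^-6 cm/s

Compound 3 stands second highest of the three numbers in this assay. Compound 1 sits lower and compound 2 sits higher, and both gaps lie beyond the usual scatter of this kind of measurement.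

Compound 4 `Cc1c(Cl)cccc1CCCCOc1ccc(C#Cc2cccc3c(CCC(=O)O)c(C)n(CCCCC(=O)O)c23)cc1` has not yet been measured. It differs from compound 3 in one place: carboxymethyl in place of carboxy on a saturated chain carbon bound to an aromatic carbon. Within the data shown here, the same difference, cut one bond further out, reads carboxymethyl to 2-carboxyethyl, which is the only measured step that bears on it. That step, a 5.0-fold lower number from compound 2 to compound 3 (0.70 log units; beyond the scatter), ran from the longer chain to the shortest one and gave a clear drop. Compound 4 carries a chain of intermediate length between compound 3 and compound 2, so the expected move in this assay is upward from compound 3, of a size smaller than the measured step between compound 2 and compound 3, though a number within the scatter of compound 3 cannot be ruled out on these data alone.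

Compound 4 is therefore expected to read 2.5 10^-6 cm/s in this assay, with a likely range from 1 10^-6 cm/s to 6 10^-6 cm/s. The expected step from compound 3 is a 2.5-fold higher number from compound 3 to compound 4 (0.40 log units; beyond the scatter).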

Compound 4, apparent permeability: 4.6 10^-6 cm/s
Beside the measured number, compound 4's estimate is 1.8-fold (0.26 log units) below it; the measured number falls inside the stated range.
By their numbers in this assay, from the lowest: compound 1; then compound 3; then compounds 4 and 2 (each within the scatter of the next).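

In this assay, the chain on the saturated carbon bound to an aromatic carbon now resolves into three measured lengths, and the response to length is uneven. The change from carboxy to carboxymethyl gives a 4.6-fold higher number from compound 3 to compound 4 (0.66 log units; beyond the scatter), which accounts for about the whole of the earlier 5.0-fold lower number from compound 2 to compound 3 (0.70 log units; beyond the scatter), while the further change at the chain end gives only a 1.1-fold lower number from compound 2 to compound 4 (0.04 log units; within the scatter), so compound 2 and compound 4 cannot be told apart in this assay. Among these three compounds, the sensitivity to chain length therefore sits at the step between carboxy and carboxymethyl, and not evenly along the series; nothing available gives a cause for this step.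

Whether a chain longer than 2-carboxyethyl would stay level with compound 2 and compound 4 remains open, since the series shown ends at that length. Also open, from the compounds shown here alone, is whether a primary amide or a tetrazole in place of the carboxylic acid at the end of this chain would show the same dependence on length, and whether the pattern holds with the other acid chain on the shared core changed.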